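Swapping phenyl for pyridin-4-yl in compound 3

A few compounds are considered here, and "the series" means these few. Any claim that something is new, unique, unknown or untested is made for them only; others in the source may bear on it.

Measured so far in a physicochemical assay for lipophilicity, at pH 7.4; a higher number here means a more lipophilic compound, a lower number a more polar compound
- Compound 1 `CCOc1ccc2c(c1)C=CN(C)C(=O)C2C` gives 5
- Compound 2 `C[C@H]1C(=O)N(C)C=Cc2cc(OC(CO)CO)ccc21` gives 1.3
- Compound 3 `CCS(=O)(=O)c1ccc2c(c1)C(c1ccccc1)=CN(C)C(=O)C2C` gives 5.1

Compound 3 at 5.1 and compound 1 at 5 lie within the scatter of each other, while compound 2 at 1.3 lies far lower, beyond the scatter. Compound 4 `CCS(=O)(=O)c1ccc2c(c1)C(c1ccncc1)=CN(C)C(=O)C2C` carries pyridin-4-yl in place of phenyl on a double-bonded ring carbon and otherwise matches compound 3. Among the measured compounds shown here, no measured pair shows this swap, so the expectation rests on the structural change alone. In this assay the expected change is a number 1.20 log units lower from compound 3 to compound 4 (beyond the scatter) as a fall beyond the scatter. The estimate for compound 4 is 3.9 with an expected range from 3.2 to 4.5 until a measurement arrives.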

Compound 4, distribution coefficient: 2.8
Compound 4: middle estimate off by 1.10 log units, on the high side, and the stated range ends above it.
By their numbers in this assay, from the lowest: compound 2; then compound 4; then compounds 1 and 3 (each within the scatter of the next).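

In this assay, among the compounds shown here, the group on this double-bonded ring carbon clearly matters: pyridin-4-yl in place of phenyl gives a number 2.30 log units lower from compound 3 to compound 4 (beyond the scatter), the first change at a single place in these compounds. The two groups have the same number of heavy atoms and differ by one ring nitrogen, which adds one hydrogen-bond acceptor. Nothing available explains the size of this step. Still open, on these data alone, is whether pyridin-3-yl, with the ring nitrogen elsewhere, would give a similar step. Also open, as far as these compounds go, is how an aminophenyl group would compare at this position.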